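Piperidine nitrogen substituent change in a GIP receptor agonist series

A few compounds are considered here, and "the series" means these few. Any claim that something is new, unique, unknown or untested is made for them only; others in the source may bear on it.

Measured so far:
compound 1 `CC(C)OC(=O)N1CCC(Oc2ncnc3c2CCN3c2ccc(S(C)(=O)=O)cc2)CC1` — 126 nM
compound 2 `CC(C)COC(=O)N1CCC(Oc2ncnc3c2CCN3c2ccc(S(C)(=O)=O)cc2F)CC1` — 25.1 nM

In a functional assay on CHO-K1 cells for agonist activity at Glucose-dependent insulinotropic receptor (Homo sapiens), read by a luciferase reporter, with a stated time of 5 h (a higher number here means that more compound is needed for the effect, a lower number that less compound is needed), compound 2 gives 25.1 nM, the lower of the two numbers; in the same assay compound 1 gives 126 nM, a gap beyond the usual scatter. Going by the values given here, no single-change pair has been measured, so no step size from the series itself is available.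

Compound 3 `CS(=O)(=O)c1ccc(N2CCc3c(OC4CCN(C(=S)Sc5ccccc5)CC4)ncnc32)c(F)c1` is not yet measured. It differs from compound 2 by a group of 9 heavy atoms (7 carbon, 2 sulfur; one six-membered aromatic ring of carbon only) in place of a group of 7 heavy atoms (5 carbon, 2 oxygen; no ring), on an amine nitrogen in a ring. Nothing in the two measured compounds speaks to a change of this kind on the amine nitrogen in the ring; the carbamate is the only substituent seen there so far. The expectation is therefore a modest loss, with wide uncertainty: the step from compound 2 to compound 3 is estimated at a 4.0-fold higher number from compound 2 to compound 3 (0.60 log units; beyond the scatter). Compound 3 is expected to give about 100 nM in this assay, in a range from 20 nM to 600 nM.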

Compound 3, half-maximal effective concentration: 12.6 nM
For compound 3 the middle estimate is 7.9-fold (0.90 log units) above the measured one, outside the stated range (below it).
By their numbers in this assay, from the lowest: compounds 3 and 2 (each within the scatter of the next); then compound 1.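

In this assay, placing the group of two sulfur atoms and a six-membered aromatic ring on the amine nitrogen in the ring, in place of isobutoxycarbonyl, gives a 2.0-fold lower number from compound 2 to compound 3 (0.30 log units; within the scatter). Compound 2 and compound 3 therefore stand level, which shows that this position accepts a group with an aromatic ring and no oxygen atoms, so the carbamate is not needed here for this level of agonist activity. No available data bear on why the two groups read alike.

Going by these compounds, it remains open whether a simple amide, an alkyl amine or a phenyl carbamate on this nitrogen would hold the same level. On these data alone, it is also open whether the sulfur atoms or the aromatic ring matter more, as the two change together in this pair.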